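Swapping Ethyl for Methylphenyl: Expected Cell Tolerance

The compounds below may be only part of what the source reports. "The series", "measured", "known", "first", "only" and "open" are said of these compounds alone.

Compound 1, `CCC[C@H](CCn1cncn1)c1ccccc1`: 58.4 ug/mL in an ADME assay on HEp-2 cells (Homo sapiens) for cytotoxicity, read by MTT assay, with a stated time of 3 days; a higher number here means that more compound is tolerated, a lower number that less compound is tolerated
Compound 2, `CCC[C@H](CCn1cncn1)c1ccc(C)cc1`: 45.7 ug/mL

Compound 1 gives the highest of the two numbers; compound 2 sits nearest, a 1.3-fold lower number from compound 1 to compound 2 (0.11 log units; within the scatter). Compound 3, `Cc1ccc(C[C@H](CCn2cncn2)c2ccccc2)cc1`, is not yet measured in this assay. It differs from compound 1 in one place: 4-methylphenyl in place of ethyl on a saturated chain carbon, two bonds along the chain from an aromatic carbon. Among the compounds with values here, only the step from compound 1 to compound 2 bears on this change, and only in part, in that it too brings a methyl onto an aromatic carbon. Within the data shown here, the entering ring has no measured counterpart, so a modest downward step a 1.7-fold lower number from compound 1 to compound 3 (0.22 log units; within the scatter) is expected, roughly at the edge of the scatter. Compound 3 is estimated at 35 ug/mL, between 15 ug/mL and 75 ug/mL.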

Compound 3, half-maximal cytotoxic concentration: 38.8 ug/mL
Beside the measured number, compound 3's estimate is 1.1-fold (0.04 log units) below it; the range from low to high includes it.
By their numbers in this assay, from the lowest: compounds 3, 2 and 1 (each within the scatter of the next).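

At this saturated chain carbon, ethyl gives way to 4-methylphenyl, which brings in a whole six-membered aromatic ring, and this assay shows only a 1.5-fold lower number from compound 1 to compound 3 (0.18 log units; within the scatter). Within the data shown here, the earlier step changed only the aromatic ring already present, so this is the first sign that the chain carbon can carry a ring without a change that stands clear of the scatter. Nothing measured here offers a reason for this result.

From the compounds shown here alone, whether an amine, a carboxylic acid or a longer chain at this carbon would also stay within the scatter remains open. So does whether plain phenyl would behave like 4-methylphenyl here.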